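The source may report more compounds than this note shows. Statements on the series, on what has been measured and on what is new or still open speak of the compounds shown alone.

In an assay for displacement of a labelled ligand from Apoptosis regulator Bcl-2 (Homo sapiens), read by fluorescence polarization, with a stated time of 30 min (a higher number here means a weaker inhibitor, a lower number a stronger inhibitor), compound 1 `CCOc1ccc(-c2c(NC(=O)c3ccccc3)c(C(=O)O)nn2-c2ccc(Oc3ccccc3)cc2)cc1` gives 855 nM, compound 2 `CCOc1ccc(-c2c(NC(=O)c3ccc(C(C)(C)C)cc3)c(C(=O)O)nn2-c2ccc(Oc3ccccc3)cc2)cc1` gives 406 nM, and compound 3 `CCOc1ccc(-c2c(NC(=O)c3ccc(OC(C)C)cc3)c(C(=O)O)nn2-c2ccc(Oc3ccccc3)cc2)cc1` gives 28 nM. Compound 3 therefore stands at the lowest number of the three: the step of a 31-fold lower number from compound 1 to compound 3 (1.48 log units; beyond the scatter) is large, the step of a 15-fold lower number from compound 2 to compound 3 (1.16 log units; beyond the scatter) is likewise large, and the step of a 2.1-fold lower number from compound 1 to compound 2 (0.32 log units; beyond the scatter) is modest. All three measured steps alter one and the same part of the shared structure, and compound 4 `CC(C)Oc1ccc(C(=O)Nc2c(C(=O)O)nn(-c3ccc(Oc4ccccc4)cc3)c2-c2ccc(OCc3ccccc3)cc2)cc1` keeps that part exactly as in compound 3. What compound 4 changes instead is phenyl in place of methyl on a saturated chain carbon bound to an oxygen on an aromatic ring; the same difference, cut one bond further out, reads ethoxy to benzyloxy. Going by the values given here, no measured step touches this place, so the numbers so far give no direction for it. The expectation for compound 4 in this assay is thus a step of a 1.1-fold higher number from compound 3 to compound 4 (0.03 log units; within the scatter), that is, nothing beyond the scatter. Compound 4 is estimated at 30 nM, with a range from 8 nM to 120 nM.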

Compound 4, inhibition constant: > 10000 nM
Compound 4: a limit, no number; the forecaster's own chance of this, stated with the estimate: 2%; at least 330-fold (2.52 log units) between middle value and limit.
By their numbers in this assay, from the lowest: compound 3; then compound 2; then compound 1. At a limit, above all of these: compound 4.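

In this assay, the place on a saturated chain carbon bound to an oxygen on an aromatic ring proves highly sensitive: phenyl in place of methyl, read as ethoxy to benzyloxy, gives an at least 350-fold higher number from compound 3 to compound 4 (2.55 log units; beyond the scatter). The isopropoxy group behind the largest earlier gain, a 31-fold lower number from compound 1 to compound 3 (1.48 log units; beyond the scatter), is kept unchanged in compound 4, so that gain does not protect against this change at the second place. Compound 4 gives a limit of the assay, not a number: the limit of > 10000 nM in this assay, at which 1 of the 4 values shown sits.

Only ethoxy and benzyloxy are shown at this place, so it remains open whether a shorter group such as methoxy, a longer chain such as propoxy, or a terminal amine would be tolerated. Also open, from the compounds shown here alone, is whether a phenyl at this place would cost as much with the unsubstituted benzamide of compound 1.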